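Methyltriazolyl Replacing Anilino on a Shared Triazine-Type Core

A few compounds are considered here, and "the series" means these few. Any claim that something is new, unique, unknown or untested is made for them only; others in the source may bear on it.

Measured so far:
compound 1, `CNc1nc(NC2(C#N)CCCCC2)nc(-n2cncn2)n1`: > 5000 nM
compound 2, `CNc1nc(Nc2ccccc2)nc(NC2(C#N)CCCCC2)n1`: > 5000 nM

Of the compounds shown here, two have been measured in an in vitro assay on Sf21 cells for inhibition of high affinity 3',5'-cyclic-AMP phosphodiesterase 7A (Homo sapiens); a lower number here means a stronger inhibitor, a higher number a weaker inhibitor. Compound 1 gives > 5000 nM, which is a limit of the assay rather than a number. Compound 2 gives > 5000 nM, again a limit. The step that the two limits leave unreadable from compound 1 to compound 2 therefore cannot be read, because both values sit at the limit of > 5000 nM in this assay, at which 2 of the 2 values shown sit.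

Compound 3 `CNc1nc(NC2(C#N)CCCCC2)nc(-n2cnc(C)n2)n1` differs from compound 2 by 3-methyl-1H-1,2,4-triazol-1-yl in place of anilino on an aromatic carbon. For the measured compounds named here, the only measured step bears on this change in the reverse direction, but its size is not readable, so neither a direction nor a size beyond the scatter can be drawn from it. Compound 3 is expected to give an estimated 10000 nM, within a range from 3000 nM to 40000 nM, most probably reported once more as a limit. The step that the limit leaves unreadable from compound 2 to compound 3 is accordingly expected to be unreadable rather than a measured change.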

Compound 3, half-maximal inhibitory concentration: > 5000 nM
Compound 3 ended at the assay's limit (the forecaster's own chance of this, stated with the estimate: 85%); the middle value is on the limit's open side.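

For the compounds shown here, no step among compound 1, compound 2 and compound 3 can be read, because all three stop at the same limit: the limit of > 5000 nM in this assay, at which 3 of the 3 values shown sit. The compounds shown leave open how anilino, 1H-1,2,4-triazol-1-yl and 3-methyl-1H-1,2,4-triazol-1-yl compare on the shared core in this assay.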